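Benzylsulfanyl in place of butylamino at the assay limit

The compounds below may be only part of what the source reports. "The series", "measured", "known", "first", "only" and "open" are said of these compounds alone.

In an ADME assay on HFF cells (Homo sapiens) for cytotoxicity, with a stated time of 8 days (on this read-out higher numbers stand for lower toxicity in this test and lower numbers for higher toxicity in this test), compound 1 (`CC(C)Sc1nc(N)nc2c1ncn2/C=C1/CC1(CO)CO`) gives > 300000 nM, which is a limit and not a number. Compound 2 (`CCCCNc1nc(N)nc2c1ncn2/C=C1/CC1(CO)CO`) gives > 300000 nM, which is also a limit. Compound 2 therefore stands with compound 1 at the limit of > 300000 nM in this assay, at which 2 of the 2 values shown sit. Among the measured compounds shown here, the only measured step, a step that the two limits leave unreadable from compound 1 to compound 2, has no readable size, so the series offers no graded trend to extend.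

Compound 3 (`Nc1nc(SCc2ccccc2)c2ncn(/C=C3/CC3(CO)CO)c2n1`) carries benzylsulfanyl in place of butylamino on an aromatic carbon. The closest guide is compound 1, whose isopropylsulfanyl group occupies the same carbon and which gives > 300000 nM in this assay. For the measured compounds named here, no measured compound yet carries the six-membered aromatic ring that enters here, so some allowance toward lower numbers, meaning higher toxicity in this test, is warranted. The expected step is an at least 1.5-fold lower number from compound 2 to compound 3 (0.17 log units; that floor lies within the scatter), small if it can be read at all. For compound 3 the estimated value is 200000 nM, with an expected range of 60000 nM to 300000 nM, and a further report of only a limit is quite possible.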

Compound 3, half-maximal cytotoxic concentration: > 300000 nM
Compound 3 ended at the assay's limit (the forecaster's own chance of this, stated with the estimate: 60%); at least 1.5-fold (0.17 log units) between middle value and limit.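

Compound 1, compound 2 and compound 3 all end at the same assay limit in this assay, so no step among them can be read: the limit of > 300000 nM in this assay, at which 3 of the 3 values shown sit.

The compounds shown leave open how the three compare past that limit, and whether any group on this aromatic carbon would bring the read-out down to a measurable number.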